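Cyclohexyl in place of 4-hydroxyphenyl: an expectation

This account rests on a few compounds, and the source may have more. Where it says the series, first, only, none or still open, it means among the compounds named here.

Compound 1 `Cc1ccc(-c2ccc(NCc3ccccc3O)cc2)cc1`: 3790 nM
Compound 2 `Oc1ccc(-c2ccc(NCc3ccccc3O)cc2)cc1`: "not active" (no number reported)

Of the compounds shown here, two have been measured in a functional assay on Jurkat cells (Homo sapiens) for activation, with a stated time of 24 h; on this read-out higher numbers stand for an effect only at larger amounts of compound and lower numbers for an effect already at smaller amounts. Compound 1 gives 3790 nM in this assay. Compound 2, in the same assay, is recorded as "not active" (no number reported), so no number stands for it, only the statement that no effect was seen. Where compound 2 stands can therefore only be said in words: it shows nothing, while compound 1 shows a measurable effect.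

The step to compound 3 `Oc1ccccc1CNc1ccc(C2CCCCC2)cc1` consists of cyclohexyl in place of 4-hydroxyphenyl on an aromatic carbon. Within the data shown here, no measured pair shows this change, so its size in this assay cannot be read off from the data; the only guidance is that compound 1, which also lacks the hydroxyl on that outer ring, gives a number. A move from an inactive compound to an active one is expected, of moderate size. Compound 3 is expected to give about 5000 nM in this assay, within a range of 1500 nM to 20000 nM.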

Compound 3, half-maximal effective concentration: 8800 nM
Beside the measured number, compound 3's estimate is 1.8-fold (0.25 log units) below it; measured number inside the range.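

With cyclohexyl in this place, on an aromatic carbon, compound 3 still gives a number in this assay, so among the compounds shown an aromatic outer ring is not needed for an effect, while compound 2, with 4-hydroxyphenyl, is recorded as not active. Cyclohexyl in place of 4-methylphenyl brings a 2.3-fold higher number from compound 1 to compound 3 (0.37 log units; beyond the scatter), so the change is tolerated at a modest cost on this read-out. No measurement at hand gives a reason for either difference.

The compounds shown leave open whether an unsubstituted phenyl or a 4-methoxyphenyl group would give a number in this assay, and so whether the free hydroxyl alone separates compound 2 from compound 1. They also leave open how an amine or a carboxylic acid on the cyclohexyl ring would read out.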